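Fluoro in place of hydrogen: an estimate for compound 4

This account rests on a few compounds, and the source may have more. Where it says the series, first, only, none or still open, it means among the compounds named here.

Measured so far:
compound 1, `O=C(O)c1cc(-c2ccccc2)ccc1O`, 54 mg/kg
compound 2, `O=C(O)c1cc(-c2cccc(F)c2)ccc1O`, 40 mg/kg
compound 3, `Cc1cc(-c2ccccc2)cc(C(=O)O)c1O`, 60 mg/kg

These three compounds were measured in a functional assay on the whole organism with Rattus norvegicus as the target; on this read-out lower numbers stand for an effect already at smaller amounts and higher numbers for an effect only at larger amounts of compound. Compound 4, `Cc1cc(-c2ccc(F)cc2)cc(C(=O)O)c1O`, has not yet been measured there. Compound 4 arises from compound 3 by a single change, (fluoro in place of hydrogen on an aromatic carbon). The same change, counted as fluoro in place of hydrogen on an aromatic carbon, leads from compound 1 to compound 2, and there it made a step of a 1.4-fold lower number from compound 1 to compound 2 (0.13 log units; within the scatter). The two cores differ by methyl in place of hydrogen on an aromatic carbon, which made a step of a 1.1-fold higher number from compound 1 to compound 3 (0.05 log units; within the scatter). The two places are not the same word for word: in compound 2 the fluoro stands meta to a large group, in compound 4 para to a large group, so the change is of the same kind rather than the same. Because a 1.4-fold lower number from compound 1 to compound 2 (0.13 log units; within the scatter) lay within the scatter, only a small step is expected from compound 3 to compound 4 in this assay, estimated as a 1.3-fold lower number from compound 3 to compound 4 (0.12 log units; within the scatter). For compound 4 the expected value in this assay is 45 mg/kg, with a likely range from 25 mg/kg to 80 mg/kg.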

Compound 4, dose for half-maximal effect: 60 mg/kg
The estimate for compound 4 lay 1.3-fold (0.12 log units) below the measured number; the measured number falls inside the stated range.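

In this assay, fluoro in place of hydrogen on an aromatic carbon gave no change at the digits printed from compound 3 to compound 4 (within the scatter), and the two steps for this change agree when set side by side: the same change on two cores in this assay, a 1.4-fold lower number (0.13 log units; within the scatter) from compound 1 to compound 2 and no change at the digits printed (within the scatter) from compound 3 to compound 4, 1.4-fold (0.13 log units) apart, within the scatter of two such steps

Across these two cores, which differ by a methyl, the change therefore carried over as a step that cannot be told from the scatter. Among the compounds shown here, this does not show that fluoro is without effect or that a larger step would carry over in the same way, and with only two pairs, and the fluoro para to a large group in compound 4 but at a different place in compound 2, the core and the place of the fluoro cannot be told apart.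

The compounds shown leave open whether a chloro, a methoxy or an amine on that same aromatic carbon would give a step beyond the scatter. They also leave open whether the fluoro step would hold with a longer chain in place of the methyl.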